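Oxazole carboxamide piperazines: microsomal stability notes

The compounds below may be only part of what the source reports. "The series", "measured", "known", "first", "only" and "open" are said of these compounds alone.

Measured so far:
- Compound 1 `Cc1nc(-c2ccc(F)cc2)c(C(=O)N2CCN(c3cc(Cl)cc(Cl)c3)CC2)o1`: 71.8%
- Compound 2 `COc1cc(OC)cc(N2CCN(C(=O)c3oc(C)nc3-c3ccccc3)CC2)c1`: 15.8%

In an ADME assay (liver) for metabolic stability, with Liver microsome (Homo sapiens) as the target, read by LC-MS, using microsomes, with a stated time of 1 h, tested at 5 uM (on this read-out higher numbers stand for a more stable compound and lower numbers for a less stable compound), compound 1 gives 71.8%, whereas compound 2 gives 15.8%, the lower of the two values, and the gap to compound 1 lies beyond the scatter.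

Compound 3 `Cc1nc(-c2ccccc2)c(C(=O)N2CCN(c3cc(Cl)cc(Cl)c3)CC2)o1` is not yet measured. Compared with compound 2 the change is 3,5-dichlorophenyl in place of 3,5-dimethoxyphenyl on an amine nitrogen in a ring. The group that enters is the same 3,5-dichlorophenyl that compound 1 carries on its ring amine nitrogen, and compound 1 is the more stable of the two measured compounds. On that basis a step upward, well beyond the scatter, is expected in this assay for compound 3: the expected step is a number 44.2 percentage points higher from compound 2 to compound 3 (beyond the scatter). The estimate for compound 3 in this assay is 60%, within a range of 35% to 85%.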

Compound 3, percent of the compound remaining: 66.3%
Compound 3: middle estimate off by 6.3 percentage points, on the low side, and the stated range covers the measured number.
By their numbers in this assay, from the lowest: compound 2; then compounds 3 and 1 (each within the scatter of the next).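

In this assay, for the compounds shown here, 3,5-dichlorophenyl in place of 3,5-dimethoxyphenyl on the amine nitrogen in the ring gives a number 50.5 percentage points higher from compound 2 to compound 3 (beyond the scatter), the first reading of this position with the rest of the structure held constant, and the change is large. Hydrogen in place of fluoro on an aromatic carbon gives a number 5.5 percentage points lower from compound 1 to compound 3 (within the scatter), so with 3,5-dichlorophenyl on the ring nitrogen this second change does not separate the two compounds in this read-out. The data shown offer no explanation for the step at the ring nitrogen.

Only two substituted phenyl groups are shown on that nitrogen, so it remains open how an unsubstituted phenyl, a trifluoromethyl-bearing phenyl or a pyridine ring would read there. On these data alone, whether fluoro in place of hydrogen would also read within the scatter with 3,5-dimethoxyphenyl on the ring nitrogen is equally open.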